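Azole for pyrrolidine on the aryl ring of compound 3

The compounds below may be only part of what the source reports. "The series", "measured", "known", "first", "only" and "open" are said of these compounds alone.

Compound 3 `CN1CCC(S(=O)(=O)c2ccc3nc(NC(=O)NC(=O)c4cc(N5CCCC5)ccc4Cl)sc3c2)CC1` gives 0.92 nM in an assay on HEK293 cells for displacement of a labelled ligand from growth hormone secretagogue receptor type 1 (Homo sapiens), with a stated time of 60 min (a higher number here means a weaker inhibitor, a lower number a stronger inhibitor), the lowest of the three numbers measured. Compound 1 `CN1CCN(CCCS(=O)(=O)c2ccc3nc(NC(=O)NC(=O)c4cccc(-n5cccn5)c4Cl)sc3c2)CC1` gives 8.8 nM and compound 2 `CS(=O)(=O)c1ccc2sc(NC(=O)NC(=O)c3ccccc3Cl)nc2c1` gives 4700 nM; both gaps to compound 3 lie beyond the scatter, so compound 3 stands as the strongest inhibitor of the set.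

Compound 4 `Cc1ccnn1-c1ccc(Cl)c(C(=O)NC(=O)Nc2nc3ccc(S(=O)(=O)C4CCN(C)CC4)cc3s2)c1` carries 5-methyl-1H-pyrazol-1-yl in place of pyrrolidin-1-yl on an aromatic carbon. Among the compounds with values here, no measured pair isolates this exchange, so its size is not known. The surviving potency of compound 1, at 8.8 nM, with a different amide aryl substitution suggests the series tolerates such changes, yet the replacement of a saturated ring by an aromatic one is expected to cost a modest amount, a step of a 2.7-fold higher number from compound 3 to compound 4 (0.43 log units; beyond the scatter). Compound 4 is therefore estimated at 2.5 nM, within 0.8 nM to 8 nM.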

Compound 4, half-maximal inhibitory concentration: 33 nM
Beside the measured number, compound 4's estimate is 13-fold (1.12 log units) below it, outside the stated range (above it).
By their numbers in this assay, from the lowest: compound 3; then compound 1; then compound 4; then compound 2.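

Within the data shown here, this is the first pair to isolate a change at this position, and in this assay the exchange is large, with a 36-fold higher number from compound 3 to compound 4 (1.55 log units; beyond the scatter) on going from pyrrolidin-1-yl to 5-methyl-1H-pyrazol-1-yl. The aromatic carbon para to the chloro group is therefore sensitive to the group it carries. No measurement shown accounts for the size of this step.

From the compounds shown here alone, the exchange alters the ring and adds a methyl group at once, so their separate contributions remain open. Unsubstituted 1H-pyrazol-1-yl or an open-chain dimethylamino group at this place would help to separate them.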